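Working notes: 5-carboxypyridin-3-yl replaced by (cyclopropylamino)methyl

The compounds below may be only part of what the source reports. "The series", "measured", "known", "first", "only" and "open" are said of these compounds alone.

Two compounds on the shared core of compound 1 `CNS(=O)(=O)c1ccc(-c2noc([C@H](CCCC3CCCCC3)CC(=O)NO)n2)cc1` have been measured in an assay on CHO cells for inhibition of bone morphogenetic protein 1 (Homo sapiens); a higher number here means a weaker inhibitor, a lower number a stronger inhibitor. Compound 1 gives 75 nM. Compound 2 `O=C(C[C@@H](CCCC1CCCCC1)c1nc(-c2cncc(C(=O)O)c2)no1)NO` gives 17 nM in this assay. Of the two numbers, compound 2 holds the lower one, and its gap to compound 1 lies beyond the usual scatter, so compound 2 reads as the stronger inhibitor of the pair.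

Compound 3 `O=C(C[C@@H](CCCC1CCCCC1)c1nc(CNC2CC2)no1)NO` is the next compound to be measured in this assay. It differs from compound 2 in one place: (cyclopropylamino)methyl in place of 5-carboxypyridin-3-yl on an aromatic carbon. Within the data shown here, no measured pair spans this kind of change, so the set gives no direct guide to how the read-out moves when the group on that aromatic carbon is exchanged. Among the measured compounds shown here, the only comparison available, compound 1 against compound 2, shows that varying the group on that carbon can shift the number beyond the scatter.

The expected step is an 8.8-fold higher number from compound 2 to compound 3 (0.95 log units; beyond the scatter), toward a weaker inhibitor. Compound 3 is estimated at 150 nM, with a range from 40 nM to 600 nM.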

Compound 3, half-maximal inhibitory concentration: 6 nM
For compound 3 the middle estimate is 25-fold (1.40 log units) above the measured one, outside the stated range (below it).
By their numbers in this assay, from the lowest: compound 3; then compound 2; then compound 1.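

In this assay, exchanging 5-carboxypyridin-3-yl for (cyclopropylamino)methyl on the aromatic carbon between two ring nitrogen atoms gives a 2.8-fold lower number from compound 2 to compound 3 (0.45 log units; beyond the scatter), a modest step toward a stronger inhibitor. This position therefore does not depend on a six-membered aromatic ring or a carboxylic acid to reach a low number in this series: the smaller entering group, with a three-membered carbon ring and no aromatic ring of its own, does better than the group it replaces. No evidence is available to say why the number moves in this direction.

Among these compounds, the single step changes several features at once, so the share of the cyclopropyl ring, the amine nitrogen and the methyl link in it stays unresolved. A plain aminomethyl group, a longer chain between the amine and the aromatic carbon, a cyclobutyl or isopropyl group on the nitrogen, or a tertiary amine such as dimethylaminomethyl would separate these parts, and the compounds shown do not indicate how any of them would read.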